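Heteroaryl swaps at the shared core: pyrazole for thiazole

This account rests on a few compounds, and the source may have more. Where it says the series, first, only, none or still open, it means among the compounds named here.

Compound 1 `Cc1csc(-c2ncnc3c2ncn3C2O[C@H](CO)[C@@H](O)[C@H]2O)n1` carries a 4-methyl-1,3-thiazol-2-yl group on the shared core. In a functional assay on CCRF-CEM cells (Homo sapiens) for inhibition (on this read-out higher numbers stand for weaker inhibition and lower numbers for stronger inhibition), compound 1 gives 6000 nM, the highest of the two numbers obtained so far. Going by the values given here, compound 3 `Cn1cccc1-c1ncnc2c1ncn2C1O[C@H](CO)[C@@H](O)[C@H]1O` gives 2000 nM in this assay, and the step of a 3.0-fold lower number from compound 1 to compound 3 (0.48 log units; beyond the scatter) is the one measured change that bears on the present case, a swap of one five-membered aromatic ring for another on the same carbon. Compound 2 `Cc1cc(-c2ncnc3c2ncn3C2O[C@H](CO)[C@@H](O)[C@H]2O)on1` was reported as "not active" (no number reported) in this assay, so a related swap can also abolish measurable inhibition.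

Compound 4 `OC[C@H]1OC(n2cnc3c(-c4cc[nH]n4)ncnc32)[C@H](O)[C@@H]1O` differs from compound 1 by 1H-pyrazol-3-yl in place of 4-methyl-1,3-thiazol-2-yl on an aromatic carbon. Given the modest gain seen for compound 3 and the loss seen for compound 2, the expected step of a 1.5-fold lower number from compound 1 to compound 4 (0.18 log units; within the scatter) in this assay is a small move toward a lower number, likely within or just beyond the scatter. Compound 4 is estimated at 4000 nM in this assay, with a range from 1000 nM to 20000 nM.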

Compound 4, half-maximal inhibitory concentration: 750 nM
Estimate against measurement, compound 4: 5.3-fold (0.73 log units) above, outside the stated range (below it).
By their numbers in this assay, from the lowest: compound 4; then compound 3; then compound 1.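

In this assay the 1H-pyrazol-3-yl group gives the largest step seen at this position, an 8.0-fold lower number from compound 1 to compound 4 (0.90 log units; beyond the scatter), and it also improves on 1-methyl-1H-pyrrol-2-yl, with a 2.7-fold lower number from compound 3 to compound 4 (0.43 log units; beyond the scatter) beyond the scatter. Five-membered aromatic rings on this aromatic carbon are therefore separated by more than the scatter, and compound 4 has the lowest of the three numbers, while compound 2 has no number to place in that order. The entering group has 1 hydrogen-bond donor where 4-methyl-1,3-thiazol-2-yl has 0 hydrogen-bond donors, but no supporting data link this difference or any other to the change in the read-out.

From the compounds shown here alone, what a phenyl group or an amine on this carbon would give remains open. Also open, going by these compounds, is whether a methyl group on the 1H-pyrazol-3-yl ring would preserve the value of compound 4.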